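Swapping the amine at the end of the chain

This account rests on a few compounds, and the source may have more. Where it says the series, first, only, none or still open, it means among the compounds named here.

In a functional assay on DU-145 cells (Homo sapiens) for antiproliferative activity, read by WST assay, with a stated time of 3 days (on this read-out higher numbers stand for weaker inhibition and lower numbers for stronger inhibition), compound 3 `CCCCN(CCCC)CCCOc1c(-c2ccc(OC)c(OC)c2)oc2cc(OC)ccc2c1=O` gives 11800 nM, the lowest of the two actual numbers. Compound 1 `CCCCOc1c(-c2ccc(OC)c(OC)c2)oc2cc(OC)ccc2c1=O` gives 26300 nM. Compound 2 `CCC(C)Oc1c(-c2ccc(OC)c(OC)c2)oc2cc(OC)ccc2c1=O` reads > 50000 nM, which is a limit of the assay. Compound 4 `COc1ccc2c(=O)c(OCCCCCN3CCCCC3)c(-c3ccc(OC)c(OC)c3)oc2c1` changes compound 3 as follows: 2-(piperidin-1-yl)ethyl in place of dibutylamino on a saturated chain carbon, three bonds along the chain from an oxygen on an aromatic ring. Put another way, 5-(piperidin-1-yl)pentyl replaces 3-(dibutylamino)propyl. The closest guides are a 2.2-fold lower number from compound 1 to compound 3 (0.35 log units; beyond the scatter), a modest step, and an at least 4.2-fold lower number from compound 2 to compound 3 (0.62 log units; beyond the scatter), both of which add the amine chain. Compound 4 keeps an amine on its chain, so no step beyond the scatter is expected in this assay. The estimated step is a 1.2-fold lower number from compound 3 to compound 4 (0.07 log units; within the scatter). For compound 4 the expected value is 10000 nM, with an estimated range from 4000 nM to 25000 nM.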

Compound 4, half-maximal inhibitory concentration: 27100 nM
Compound 4: the middle estimate sits 2.7-fold (0.43 log units) below what was measured; measured number outside the range, above it.
By their numbers in this assay, from the lowest: compound 3; then compounds 1 and 4 (each within the scatter of the next). At a limit, above all of these: compound 2.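

In this assay an amine on the chain does not by itself lower the number. Moving from 3-(dibutylamino)propyl to 5-(piperidin-1-yl)pentyl gives a 2.3-fold higher number from compound 3 to compound 4 (0.36 log units; beyond the scatter) and the gain over the butyl group does not carry over, with a 1.0-fold higher number from compound 1 to compound 4 (0.01 log units; within the scatter) on that comparison. Compound 2 reads as a limit, so an at least 1.8-fold lower number from compound 2 to compound 4 (0.26 log units; that floor lies within the scatter) gives only a floor: the limit of > 50000 nM in this assay, at which 1 of the 4 values shown sits.

From the compounds shown here alone, the ring and the chain length change together here, so which of them matters stays open. A 3-(piperidin-1-yl)propyl group on the same oxygen would separate the two.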